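Swapping One Ring for Another on Compound 1

A few compounds are considered here, and "the series" means these few. Any claim that something is new, unique, unknown or untested is made for them only; others in the source may bear on it.

Within the data shown here, compound 1 `CC(C)c1nnsc1C[S+]([O-])C(c1ccccc1)c1ccccc1` stands at the top of the three numbers measured so far: in an assay on HEK293 cells for inhibition of sodium-dependent dopamine transporter (Homo sapiens), read by scintillation counting, with stated times of 5 min and 1 min (on this read-out higher numbers stand for weaker inhibition and lower numbers for stronger inhibition), compound 1 gives 69100 nM. Its nearest neighbour is compound 3 `[O-][S+](Cc1cc(C2CC2)on1)C(c1ccccc1)c1ccccc1`, which in this assay gives 38600 nM, and the step of a 1.8-fold lower number from compound 1 to compound 3 (0.25 log units; within the scatter) is a change of the ring on a saturated chain carbon bound to a sulfur. Furthest away is compound 2 `[O-][S+](Cc1cccs1)C(c1ccc(Cl)cc1)c1ccc(Cl)cc1`, which in this assay gives 7200 nM; it differs from compound 1 in more than one place, so only the two values themselves are shown.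

Compound 4 `Cc1nc(O)cc(C[S+]([O-])C(c2ccccc2)c2ccccc2)n1` is the next compound to be measured. It differs from compound 1 as follows: 6-hydroxy-2-methylpyrimidin-4-yl in place of 4-isopropyl-1,2,3-thiadiazol-5-yl on a saturated chain carbon bound to a sulfur. Among the measured compounds shown here, the one measured step that bears on this change is the ring swap from compound 1 to compound 3, which stayed within the scatter. On that basis the author expects the step of a 1.4-fold lower number from compound 1 to compound 4 (0.14 log units; within the scatter) to be small, with no clear direction. Compound 4 is therefore estimated at 50000 nM in this assay, within a range from 15000 nM to 150000 nM.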

Compound 4, half-maximal inhibitory concentration: 3100 nM
Compound 4: middle estimate off by 16-fold (1.21 log units), on the high side; measured number below the stated range.
By their numbers in this assay, from the lowest: compound 4; then compound 2; then compounds 3 and 1 (each within the scatter of the next).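

Among these compounds, the ring on the saturated chain carbon bound to a sulfur proves able to move the number in this assay: 6-hydroxy-2-methylpyrimidin-4-yl gives a large step against both earlier rings (a 22-fold lower number from compound 1 to compound 4 (1.35 log units; beyond the scatter) and a 12-fold lower number from compound 3 to compound 4 (1.10 log units; beyond the scatter)), whereas the only earlier ring swap stayed within the scatter. Against 4-isopropyl-1,2,3-thiadiazol-5-yl, the entering group brings a six-membered aromatic ring in place of a five-membered one and adds a hydrogen-bond donor, and these compounds cannot separate those two changes. Nothing measured here accounts for the large step.

From the compounds shown here alone, it remains open whether a methoxy group or an amine in place of the hydroxy would keep the lower number. The part played by the methyl group on the new ring is equally unresolved.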